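Swapping the aryl group on the amine: compound 3 in a stability assay

This account rests on a few compounds, and the source may have more. Where it says the series, first, only, none or still open, it means among the compounds named here.

Measured so far:
- compound 1, `COC(=O)C1=C(Nc2ccc(OC)cc2)O/C(=C\c2c[nH]c3ncccc23)C1=O`, 5.1%
- compound 2, `COC(=O)C1=C(Nc2ccc(C)cc2C)O/C(=C\c2c[nH]c3ncccc23)C1=O`, 30%

Both compounds share one core and differ only in the aromatic group attached to an amine nitrogen. In an ADME assay on microsomes from liver (Rattus norvegicus) for metabolic stability, read by LC-MS, using NADPH, with a stated time of 30 min, tested at 1 uM (a higher number here means that more of the compound is left, a lower number that less of the compound is left), compound 1 gives 5.1%, while compound 2 gives 30%. Within the data shown here, the one measured step, a number 24.9 percentage points higher from compound 1 to compound 2 (beyond the scatter), therefore places compound 2 at the top of the two numbers, with compound 1 clearly behind it.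

Compound 3, `COC(=O)C1=C(Nc2ccc(F)cc2)O/C(=C\c2c[nH]c3ncccc23)C1=O`, takes the next step: 4-fluorophenyl in place of 2,4-dimethylphenyl on an amine nitrogen. Among the measured compounds shown here, no measured step covers this exchange directly; the only step in hand, a number 24.9 percentage points higher from compound 1 to compound 2 (beyond the scatter), describes a different pair of groups, so it shows only that changing this aromatic group can shift the read-out by a modest amount in either direction. The same amine nitrogen carries the new group, and the two measured values mark the span within which compound 3 is likely to fall.

On this basis compound 3 is expected to give about 15%, within 3% to 40%, an estimated step of a number 15 percentage points lower from compound 2 to compound 3 (beyond the scatter).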

Compound 3, percent of the compound remaining: 25%
Beside the measured number, compound 3's estimate is 10 percentage points below it; measured number inside the range.
By their numbers in this assay, from the lowest: compound 1; then compounds 3 and 2 (each within the scatter of the next).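

In this assay, a number 5 percentage points lower from compound 2 to compound 3 (within the scatter), so on this amine nitrogen the 4-fluorophenyl and 2,4-dimethylphenyl groups cannot be told apart, even though one carries a single fluorine and the other two methyl groups. Reading the series from compound 1 gives a different picture: a number 19.9 percentage points higher from compound 1 to compound 3 (beyond the scatter), and this exchange of methoxy for fluoro on an aromatic carbon is the only change between the two compounds, which shows that a higher number at this position does not depend on the methyl groups of compound 2. Among these three compounds, then, the 4-methoxyphenyl group of compound 1 stands apart, while nothing available here accounts for that difference in terms of a cause. With only three aromatic groups shown on this nitrogen, it remains open how the number would respond to other groups there, such as unsubstituted phenyl, 4-chlorophenyl or a non-aromatic cyclohexyl. Going by these compounds, all three compounds also share the same core, so the effect of a change elsewhere, such as a carboxylic acid in place of the ester, remains open too.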